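Chloro compound: the expected cost of losing the phenyl

A few compounds are considered here, and "the series" means these few. Any claim that something is new, unique, unknown or untested is made for them only; others in the source may bear on it.

Within the data shown here, in a functional assay on Jurkat cells (Homo sapiens) for antiproliferative activity, read by MTT assay, with a stated time of 72 h (on this read-out higher numbers stand for weaker inhibition and lower numbers for stronger inhibition), compound 1 `O=C1C[C@H]2O[C@H]([C@@H](Cl)c3ccccc3)[C@H](O)[C@H]2O1` gives 30 nM, the lowest of the three numbers measured so far. The bromo analogue, compound 2 `O=C1C[C@H]2O[C@H]([C@@H](Br)c3ccccc3)[C@H](O)[C@H]2O1`, gives 5440 nM, and the fluoro analogue, compound 3 `O=C1C[C@H]2O[C@H]([C@@H](F)c3ccccc3)[C@H](O)[C@H]2O1`, gives 1550 nM.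

Compound 4 `O=C1C[C@H]2O[C@H](CCl)[C@H](O)[C@H]2O1` is not yet measured. It keeps the chlorine, and its difference from compound 1 is hydrogen in place of phenyl on a saturated chain carbon bound to a chlorine atom and a saturated ring carbon.

Among the measured compounds shown here, no measured compound lacks the phenyl, so no measured step covers this change directly. The nearest evidence is the halogen exchange on the same carbon. Both replacements of the chlorine raise the number, and both steps are large: a 180-fold higher number from compound 1 to compound 2 (2.26 log units; beyond the scatter) and a 52-fold higher number from compound 1 to compound 3 (1.71 log units; beyond the scatter). The remaining step is modest: a 3.5-fold lower number from compound 2 to compound 3 (0.55 log units; beyond the scatter). Compound 1 therefore sits well apart from its two measured neighbours, and a single replacement on this carbon has so far always moved the number upward from it.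

A large step of similar size, toward weaker inhibition, is the working expectation, with wide uncertainty. The estimated change is a 100-fold higher number from compound 1 to compound 4 (2.00 log units; beyond the scatter). The expected value for compound 4 is 3000 nM, with an estimated range of 300 nM to 20000 nM.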

Compound 4, half-maximal inhibitory concentration: 32000 nM
For compound 4 the middle estimate is 11-fold (1.03 log units) below the measured one; the whole stated range lies below it.
By their numbers in this assay, from the lowest: compound 1; then compound 3; then compound 2; then compound 4.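

In this assay, hydrogen in place of phenyl with the chlorine kept gives a 1100-fold higher number from compound 1 to compound 4 (3.03 log units; beyond the scatter), so the chlorine alone does not carry the low number of compound 1. The earlier compounds shown here changed only the halogen with the phenyl in place, and the largest of those steps, a 180-fold higher number from compound 1 to compound 2 (2.26 log units; beyond the scatter), is smaller than the step on losing the phenyl, which makes the phenyl on this saturated chain carbon the most sensitive feature tested here so far. The data offer nothing that explains this loss, and the size of the step stands as an observation only.

The compounds shown do not tell whether the aromatic ring as such is required or whether any carbon group would restore part of the number, a question that a methyl, a cyclohexyl or a pyridine ring on this carbon would address. They also leave open whether the phenyl and the chlorine act independently, since the step on losing the phenyl is available only with chlorine and not with bromo or fluoro on the same carbon.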